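Three Measured Compounds, a Shared Core, an Untested Fourth

The source may hold more compounds than are shown below. What is called first, only, known or untested is meant among the compounds shown, and "the series" means these compounds.

Of the compounds shown here, three built on one shared core have been tested in an ADME assay on BHK cells (Mesocricetus auratus) for cytotoxicity, read by MTT assay, with a stated time of 96 h; on this read-out lower numbers stand for higher toxicity in this test and higher numbers for lower toxicity in this test. Compound 1 `CCC(=O)Nc1ccc(-c2nc3cc(C(F)(F)F)ccc3n2C2CCCCC2)cc1` gives 15000 nM. Compound 2 `CN1CCN(CC(=O)Nc2ccc(-c3nc4cc(C(F)(F)F)ccc4n3C)cc2)CC1` gives 16000 nM. Compound 3 `O=[N+]([O-])c1ccc(-c2nc3cc(C(F)(F)F)ccc3[nH]2)cc1` gives 18000 nM. All three numbers sit within the usual scatter of one another, so compound 2 stands together with compounds 1 and 3 rather than apart from either; nothing in this set tells the three apart.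

Compound 4 `Cn1c(-c2ccc(N)cc2)nc2cc(C(F)(F)F)ccc21` has not yet been measured in this assay. It differs from compound 2 in one place: hydrogen in place of ((4-methylpiperazin-1-yl)methyl)carbonyl on a nitrogen on an aromatic ring. The ((4-methylpiperazin-1-yl)methyl)carbonyl group departs and a hydrogen takes its place on the nitrogen on the aromatic ring. Among the compounds with values here, no measured pair in this set shows what such a swap does, so there is no step to lean on.

The step from compound 2 to compound 4 is expected to be a 1.1-fold lower number from compound 2 to compound 4 (0.06 log units; within the scatter), that is, nothing beyond the scatter, because compound 1 gives 15000 nM and compound 3 gives 18000 nM despite carrying quite different groups at that same part of the molecule. Compound 4 is therefore estimated to give about 14000 nM in this assay, with a plausible range from 5000 nM to 40000 nM.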

Compound 4, half-maximal cytotoxic concentration: 85000 nM
For compound 4 the middle estimate is 6.1-fold (0.78 log units) below the measured one; the measured number lies above the stated range.
By their numbers in this assay, from the lowest: compounds 1, 2 and 3 (each within the scatter of the next); then compound 4.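

In this assay, within the data shown here, taking away the ((4-methylpiperazin-1-yl)methyl)carbonyl group and leaving hydrogen on the nitrogen on the aromatic ring gives a 5.3-fold higher number from compound 2 to compound 4 (0.73 log units; beyond the scatter), the first change in this set that lies beyond the scatter. The three earlier compounds could not show this, as they sit within the scatter of one another and no two of them differ in one place only. Within this pair, then, the compound carrying the larger group is the more toxic in this test, but nothing available explains the step.

A single step cannot say whether the difference belongs to the whole departing group or only to one part of it, such as the ring or the carbonyl. On these data alone, an acetyl group on the same nitrogen would keep the carbonyl without the ring and so begin to separate the two, and it also remains open whether the same swap would give a similar step with the cyclohexyl group of compound 1 in place of the methyl group.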